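The source may hold more compounds than are shown below. What is called first, only, known or untested is meant among the compounds shown, and "the series" means these compounds.

Measured so far:
compound 1 `COc1ccc2c(c1)CCc1ccc(OC)c(c1)Oc1ccc(cc1)C(O)C(Br)c1cccc(c1)O2` — 11.9%
compound 2 `Nc1nc2c(s1)-c1cccc(c1)Oc1ccc(O)cc1CCc1ccc(O)c(c1)Oc1ccc-2cc1` — 10.1%
compound 3 `COc1ccc2c(c1)CCc1ccc(OC)c(c1)Oc1ccc(cc1)-c1nc(NN)sc1-c1cccc(c1)O2` — 18.8%

In a functional assay on K562/A02 cells (Homo sapiens) for cytotoxicity, read by MTT assay, with a stated time of 48 h, tested at 10 uM (a lower number here means less inhibition, a higher number more inhibition at the concentration tested (going by the name of the read-out)), compound 2 gives 10.1%, the lowest of the three numbers, though compound 1 and compound 3 both sit within the scatter of it, so no order among the three can be read. Going by the values given here, no pair of measured compounds differs in one place, so no measured step is available to lean on.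

Compound 4 `NNc1nc2c(s1)-c1cccc(c1)Oc1ccc(O)cc1CCc1ccc(O)c(c1)Oc1ccc-2cc1` differs from compound 2 in one place: amino in place of hydrogen on a nitrogen on an aromatic ring. Among the compounds with values here, with no measured step of this kind, the change is expected to move the number by no more than the scatter. The step expected is a number 3.9 percentage points higher from compound 2 to compound 4 (within the scatter), within the scatter. Compound 4 is expected to give 14%, in a range from 5% to 26%.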

Compound 4, a percentage reported as inhibition, at one concentration (the size of the read-out at that concentration, not a potency): 13.7%
Beside the measured number, compound 4's estimate is 0.3 percentage points above it, and the stated range covers the measured number.
By their numbers in this assay, from the lowest: compounds 2, 1, 4 and 3 (each within the scatter of the next).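

In this assay, amino in place of hydrogen on a nitrogen on an aromatic ring gives a number 3.6 percentage points higher from compound 2 to compound 4 (within the scatter), the first single-place step available in the series. At this position, the change therefore leaves the pair inseparable, and no effect of the added amino can be read from it. No available measurement bears on a cause for this step.

Open, going by these compounds, is whether an acetyl group or a longer alkyl chain on that nitrogen would shift the number beyond the scatter. A single step also leaves open whether the same change behaves alike on the core of compound 1.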